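The source may report more compounds than this note shows. Statements on the series, on what has been measured and on what is new or still open speak of the compounds shown alone.

The measured compounds and their values:

compound 1 `O=C(OC1CCC(CN2CCN(c3cc(=O)c4cc(C(F)(F)F)cc([N+](=O)[O-])c4s3)CC2)CC1)c1cccc(C(F)(F)F)c1`: > 64 ug/mL, a limit
compound 2 `O=C(OC1CCC(CN2CCN(c3cc(=O)c4cc(C(F)(F)F)cc([N+](=O)[O-])c4s3)CC2)CC1)C1CCC1`: > 64 ug/mL, a limit
compound 3 `CC(=O)OC1CCC(CN2CCN(c3cc(=O)c4cc(C(F)(F)F)cc([N+](=O)[O-])c4s3)CC2)CC1`: > 64 ug/mL, a limit

In an ADME assay on Vero cells (Chlorocebus sabaeus) for cytotoxicity, read by MTT assay, with a stated time of 48 h (on this read-out lower numbers stand for stronger inhibition and higher numbers for weaker inhibition), compound 1 does not give a number but only a limit of the assay. Compound 2 gives the same limit. Compound 3 gives it as well. The three measured steps, a step that the two limits leave unreadable from compound 1 to compound 2, a step that the two limits leave unreadable from compound 1 to compound 3 and a step that the two limits leave unreadable from compound 2 to compound 3, are therefore unreadable in size, and compound 1 can be placed nowhere within the set beyond (the limit of > 64 ug/mL in this assay, at which 3 of the 3 values shown sit).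

Compound 4 `COc1cccc(C(=O)OC2CCC(CN3CCN(c4cc(=O)c5cc(C(F)(F)F)cc([N+](=O)[O-])c5s4)CC3)CC2)c1` differs from compound 1 by methoxy in place of trifluoromethyl on an aromatic carbon, a change on an aromatic carbon of a six-membered aromatic ring of carbon only. Among the compounds with values here, no measured step touches this position; the three measured steps exchange the whole group on the carbonyl carbon, and all three are unreadable because of the limit of > 64 ug/mL in this assay, at which 3 of the 3 values shown sit. No direction and no size can be read from them for this assay. Compound 4 is expected to sit at the limit again, a step that the limit leaves unreadable from compound 1 to compound 4 that is expected to stay within the scatter. The estimate for compound 4 is 80 ug/mL, in the range 45 ug/mL to 150 ug/mL.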

Compound 4, half-maximal inhibitory concentration: > 64 ug/mL
Compound 4: a limit, no number; the forecaster's own chance of this, stated with the estimate: 80%; the middle value is on the limit's open side.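

In this assay compound 4 gives > 64 ug/mL, a limit and not a number. Its steps from compound 1, compound 2 and compound 3 therefore cannot be read in size: the limit of > 64 ug/mL in this assay, at which 4 of the 4 values shown sit.

The compounds shown leave open whether any of these changes shifts the read-out in this assay at all.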